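Tracing One Swapped Group in a Cell Assay

A few compounds are considered here, and "the series" means these few. Any claim that something is new, unique, unknown or untested is made for them only; others in the source may bear on it.

Measured so far in a functional assay on A549 cells (Homo sapiens) for inhibition, read by sulforhodamine B assay; on this read-out higher numbers stand for weaker inhibition and lower numbers for stronger inhibition:
Compound 1 `COC(=O)CC/C(C)=C/Cc1c(OC)c(C)c2c(c1OCC#CCN1CCN(c3ccc(C#N)cc3)CC1)C(=O)OC2`: > 50000 nM
Compound 2 `COC(=O)CC/C(C)=C/Cc1c(OC)c(C)c2c(c1OCC#CCN1CCN(C(c3ccc(F)cc3)c3ccc(F)cc3)CC1)C(=O)OC2`: 34100 nM
Compound 3 `COC(=O)CC/C(C)=C/Cc1c(OC)c(C)c2c(c1OCC#CCN1CCCc3ccccc31)C(=O)OC2`: 18000 nM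

Compound 1 reads > 50000 nM, which is a limit of the assay and not a number. Compound 3 gives 18000 nM and compound 2 gives 34100 nM, two values that lie within the usual scatter of each other.

Compound 4 `CCCCNc1ccc(CC#CCOc2c(C/C=C(\C)CCC(=O)OC)c(OC)c(C)c3c2C(=O)OC3)cc1` keeps the shared core of compound 3 but carries 4-(butylamino)phenyl in place of 1,2,3,4-tetrahydroquinolin-1-yl on a saturated chain carbon bound to a triple-bonded carbon. Within the data shown here, no two measured compounds differ in only one place, so this change has no direct precedent. The expectation therefore leans on compound 3 at 18000 nM as the starting point. The expected change in this assay, a 1.2-fold lower number from compound 3 to compound 4 (0.08 log units; within the scatter), stays within the scatter, with no clear direction. For compound 4 the estimated value is 15000 nM, with an expected range from 5000 nM to 45000 nM.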

Compound 4, half-maximal inhibitory concentration: 6970 nM
For compound 4 the middle estimate is 2.2-fold (0.33 log units) above the measured one; measured number inside the range.
By their numbers in this assay, from the lowest: compound 4; then compounds 3 and 2 (each within the scatter of the next). At a limit, above all of these: compound 1.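

Replacing 1,2,3,4-tetrahydroquinolin-1-yl with 4-(butylamino)phenyl on a saturated chain carbon bound to a triple-bonded carbon gives, in this assay, a 2.6-fold lower number from compound 3 to compound 4 (0.41 log units; beyond the scatter), so the group at this position can shift the read-out by more than the scatter, though only modestly. The change alters several things at once: the six-membered non-aromatic ring leaves, a butylamino group enters, and the hydrogen-bond donor count rises from none to one. Nothing measured here shows which of these lies behind the step.

The compounds shown leave open whether the butyl chain, the amine hydrogen or the opened ring matters most. A methylamino or dibutylamino group on the phenyl ring, or a longer chain on that nitrogen, would begin to separate these parts.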